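The source may hold more compounds than are shown below. What is called first, only, known or untested is meant among the compounds shown, and "the series" means these compounds.

Compound 2, with the structure `ClCc1ccccc1Cn1cnc2c(Cl)nc(Cl)nc21`, gives the highest number among the two compounds measured in a functional assay on NCI-H460 cells (Homo sapiens) for cytotoxicity, read by sulforhodamine B assay, with a stated time of 48 h; on this read-out higher numbers stand for weaker inhibition of growth and lower numbers for stronger inhibition of growth: compound 2 gives 8710 nM. Its nearest neighbour on this read-out is compound 1, of structure `ClCc1ccc(Cn2cnc3c(Cl)ncnc32)cc1`, which in this assay gives 1820 nM, a gap that lies beyond the usual scatter of repeated measurements. The two compounds differ in more than one place, so their values are simply set side by side here, with no single change to account for the gap.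

Compound 3, of structure `ClCc1ccccc1Cn1cnc2c(Cl)ncnc21`, has not been measured in this assay. It is reached from compound 2 by one change: hydrogen in place of chloro on an aromatic carbon. Within the data shown here, no measured pair shows the effect of this particular change, so its size and direction remain open. Since compound 2 already stands at the weak end of the range covered, a modest move toward stronger growth inhibition is expected, though a step that stays within the scatter cannot be ruled out; the expected step is a 1.9-fold lower number from compound 2 to compound 3 (0.29 log units; within the scatter). Compound 3 is therefore estimated to give 4500 nM in this assay, within a range from 1500 nM to 13000 nM.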

Compound 3, concentration for total growth inhibition: 44700 nM
For compound 3 the middle estimate is 9.9-fold (1.00 log units) below the measured one, outside the stated range (above it).
By their numbers in this assay, from the lowest: compound 1; then compound 2; then compound 3.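

In this assay, hydrogen in place of chloro on the aromatic carbon between two ring nitrogen atoms gives a 5.1-fold higher number from compound 2 to compound 3 (0.71 log units; beyond the scatter) and so marks a clear loss of growth inhibition. Among these compounds, this is the first comparison here in which only one place differs, and it shows that this carbon is not indifferent on this read-out: with the rest of the structure unchanged, the chloro group goes with the stronger inhibition of growth and its removal with the weaker. No measurement is available that would explain this step.

The compounds shown hold only chloro and hydrogen on this carbon, so they leave open how an amine or a methoxy group there would read in this assay. They also leave open whether chloro in place of the hydrogen at the same carbon of compound 1, which carries its chloromethyl group at a different place, would bring a step of similar size and the same direction.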